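Thiophene ethyl placement and MDCK cytotoxicity

The source may hold more compounds than are shown below. What is called first, only, known or untested is meant among the compounds shown, and "the series" means these compounds.

Measured compounds:
Compound 1, `CCc1csc(CN[C@@H]2C[C@H]3C[C@@H]([C@H]2C)C3(C)C)c1`: 25000 nM
Compound 2, `C[C@H]1[C@H](NCc2cccs2)C[C@H]2C[C@@H]1C2(C)C`: 25000 nM
Compound 3, `C[C@H]1[C@H](NCc2cncs2)C[C@H]2C[C@@H]1C2(C)C`: limit of > 100000 nM

In an ADME assay on MDCK cells (Canis lupus familiaris) for cytotoxicity, read by microscopy, with a stated time of 48 h (a lower number here means that less compound is tolerated, a higher number that more compound is tolerated), compound 2 gives 25000 nM and stands level with compound 1 at the digits shown. For the measured compounds named here, the value of compound 3 in this assay is a limit of the measurement and not a number, and it is the one value here of that kind (the limit of > 100000 nM in this assay, at which 1 of the 3 values shown sits).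

Compound 4, `CCc1ccsc1CN[C@@H]1C[C@H]2C[C@@H]([C@H]1C)C2(C)C`, is not yet measured. It differs from compound 2 by ethyl in place of hydrogen on an aromatic carbon. Going by the values given here, the one measured step that bears on this is no change at the digits printed from compound 1 to compound 2 (within the scatter), which removed an ethyl from the aromatic ring without moving the number beyond the scatter. The step from compound 2 to compound 3 changed the ring itself and gave an at least 4.0-fold higher number from compound 2 to compound 3 (0.60 log units; beyond the scatter), but that change is of another kind and is not directly relevant here.

Adding an ethyl on the aromatic carbon is therefore expected to leave this assay unchanged, with the step of no change at the digits printed from compound 2 to compound 4 (within the scatter) estimated as none beyond the scatter. Compound 4 is expected to give 25000 nM, with a range from 12500 nM to 60000 nM.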

Compound 4, minimum cytotoxic concentration: 25000 nM
Estimate against measurement, compound 4: no gap at the digits printed; the measured number falls inside the stated range.
By their numbers in this assay, from the lowest: compounds 1, 2 and 4 (each within the scatter of the next). At a limit, above all of these: compound 3.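

In this assay, ethyl in place of hydrogen on an aromatic carbon, next to the ring atom that bears a large group and two ring bonds from the ring sulfur, gives no change at the digits printed from compound 2 to compound 4 (within the scatter). The earlier step, no change at the digits printed from compound 1 to compound 2 (within the scatter), spoke only for the ethyl at another place on the same ring, so the series now holds two ethyl placements on this ring, with compound 1 at 25000 nM and compound 4 at 25000 nM, and neither stands apart from compound 2 beyond the scatter. Compound 3 alone carries a limit rather than a number, so the comparison at this position is between plain readings, clear of that limit: the limit of > 100000 nM in this assay, at which 1 of the 4 values shown sits.

On these data alone, whether this position stays flat for anything other than ethyl remains open, since a longer chain, an amine or a carboxylic acid on this aromatic carbon could still move the number in this assay. For the compounds shown here, also open is whether ethyl at this place would leave the reading unchanged on the 1,3-thiazol-5-yl ring of compound 3, where the ring itself, not the substituent, gave the one step beyond the scatter.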